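The source may report more compounds than this note shows. Statements on the series, on what has been measured and on what is new or still open speak of the compounds shown alone.

In an ADME assay on MDCKII-LE cells (Canis lupus familiaris) for permeability (a lower number here means that the compound crosses the layer more slowly, a higher number that the compound crosses the layer faster), compound 1 (`N#C[C@@H]1C[C@H]1CN([C@H](CCC(F)(F)F)C(N)=O)S(=O)(=O)c1ccc(Cl)cc1`) gives 9.94 10^-6 cm/s, compound 2 (`N#C[C@H]1C[C@@H](CN([C@H](CCC(F)(F)F)C(N)=O)S(=O)(=O)c2ccc(Cl)cc2)C1`) gives 24.1 10^-6 cm/s and compound 3 (`C[C@]1(C#N)C[C@H](CN([C@H](CCC(F)(F)F)C(N)=O)S(=O)(=O)c2ccc(Cl)cc2)C1`) gives 21.8 10^-6 cm/s. Compound 3 stands with compound 2 at the upper end of this small set, with a 1.1-fold lower number from compound 2 to compound 3 (0.04 log units; within the scatter), and the lower end is held by compound 1, with a 2.2-fold higher number from compound 1 to compound 3 (0.34 log units; beyond the scatter). Compound 4 (`NC(=O)[C@@H](CCC(F)(F)F)N(CC1(c2ncon2)CC1)S(=O)(=O)c1ccc(Cl)cc1`) carries 1-(1,2,4-oxadiazol-3-yl)cyclopropyl in place of 3-cyano-3-methylcyclobutyl (1-(1,2,4-oxadiazol-3-yl)cyclopropyl in place of 3-cyano-3-methylcyclobutyl on a saturated chain carbon bound to a sulfonamide nitrogen). Among the compounds with values here, no measured compound carries this oxadiazole. The closest guide is the cyclopropyl-to-cyclobutyl change, seen also in a 2.4-fold higher number from compound 1 to compound 2 (0.38 log units; beyond the scatter), here read in reverse. A downward move of similar modest size is therefore expected, a 2.1-fold lower number from compound 3 to compound 4 (0.32 log units; beyond the scatter). Compound 4 is estimated at 10.5 10^-6 cm/s, with an expected range of 4.5 10^-6 cm/s to 22 10^-6 cm/s.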

Compound 4, apparent permeability: 16.4 10^-6 cm/s
Beside the measured number, compound 4's estimate is 1.6-fold (0.19 log units) below it; the measured number falls inside the stated range.
By their numbers in this assay, from the lowest: compounds 1, 4, 3 and 2 (each within the scatter of the next, the first and the last beyond it).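

In this assay, the 1-(1,2,4-oxadiazol-3-yl)cyclopropyl group on a saturated chain carbon bound to a sulfonamide nitrogen gives no step beyond the scatter against any earlier compound (a 1.3-fold lower number from compound 3 to compound 4 (0.12 log units; within the scatter); a 1.5-fold lower number from compound 2 to compound 4 (0.17 log units; within the scatter); a 1.6-fold higher number from compound 1 to compound 4 (0.22 log units; within the scatter)). This place therefore accepts a group without a nitrile, carrying a five-membered aromatic ring, with the number staying within the scatter of all three earlier compounds. Nothing available accounts for this result. Ring and oxadiazole change together here, so their shares stay unseparated, and an oxadiazole on cyclobutyl would address that. From the compounds shown here alone, how an amine or a carboxylic acid would read at this place stays open.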